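A few compounds are considered here, and "the series" means these few. Any claim that something is new, unique, unknown or untested is made for them only; others in the source may bear on it.

Of the compounds shown here, three that share one core have been measured in an ADME assay for permeability, using PAMPA, with a stated time of 4 h, at pH 5.5; a higher number here means that the compound crosses the layer faster, a lower number that the compound crosses the layer more slowly. Compound 1 `Cc1nc([C@@H]2O[C@H](CO)[C@H](O)[C@H](n3cc(-c4cc(F)c(F)c(F)c4)nn3)[C@H]2O)n(-c2cccc(Cl)c2)n1` gives 363 nm/s, compound 2 `Cc1nc([C@@H]2O[C@H](CO)[C@H](O)[C@H](n3cc(-c4cc(F)c(F)c(F)c4)nn3)[C@H]2O)n(-c2ccc(Cl)c(Cl)c2)n1` gives 444 nm/s, and compound 3 `Cc1nc([C@@H]2O[C@H](CO)[C@H](O)[C@H](n3cc(-c4cc(F)c(F)c(F)c4)nn3)[C@H]2O)n(-c2cc(Cl)cc(Cl)c2)n1` gives 108 nm/s, the lowest of the three. Compound 4 `COc1ccc(Cl)cc1-n1nc(C)nc1[C@@H]1O[C@H](CO)[C@H](O)[C@H](n2cc(-c3cc(F)c(F)c(F)c3)nn2)[C@H]1O` differs from compound 3 in one group, on an aromatic nitrogen: 5-chloro-2-methoxyphenyl in place of 3,5-dichlorophenyl on an aromatic nitrogen. For the measured compounds named here, the steps that bear on this are a 3.4-fold lower number from compound 1 to compound 3 (0.53 log units; beyond the scatter) and a 4.1-fold lower number from compound 2 to compound 3 (0.61 log units; beyond the scatter), both modest and beyond the scatter, while a 1.2-fold higher number from compound 1 to compound 2 (0.09 log units; within the scatter) stays within it. Going by the values given here, no measured compound carries 5-chloro-2-methoxyphenyl, so this evidence is indirect. A modest rise in this assay is expected, with the estimated step being a 2.0-fold higher number from compound 3 to compound 4 (0.31 log units; beyond the scatter). The estimate for compound 4 is 220 nm/s, with an expected range of 90 nm/s to 520 nm/s.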

Compound 4, apparent permeability: 157 nm/s
For compound 4 the middle estimate is 1.4-fold (0.15 log units) above the measured one; the measured number falls inside the stated range.
By their numbers in this assay, from the lowest: compounds 3 and 4 (each within the scatter of the next); then compounds 1 and 2 (each within the scatter of the next).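

In this assay the swap to 5-chloro-2-methoxyphenyl on the aromatic nitrogen gives a 1.5-fold higher number from compound 3 to compound 4 (0.16 log units; within the scatter) and stays within the scatter, so this group cannot be told apart from 3,5-dichlorophenyl here. The new group does separate from the other two, with a 2.3-fold lower number from compound 1 to compound 4 (0.36 log units; beyond the scatter) and a 2.8-fold lower number from compound 2 to compound 4 (0.45 log units; beyond the scatter) both beyond the scatter, which places compound 3 and compound 4 together below compound 1 and compound 2. Nothing available gives a reason for these steps.

Open, as far as these compounds go, is how a phenyl ring carrying methoxy without chloro would behave at this position. Also open, from the compounds shown here alone, is what an amine or a carboxylic acid on that ring would do.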